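The compounds below may be only part of what the source reports. "The series", "measured", "known", "first", "only" and "open" are said of these compounds alone.

Compound 1, whose structure is `O=C(CCC1=CCN(CCCc2ccc(Br)cc2)C1=O)NO`, compound 2, whose structure is `O=C(CCC1=CCN(CCCc2ccc(Cl)cc2)C1=O)NO`, and compound 3, whose structure is `O=C(CCC1=CCN(Cc2cccc(Br)c2)C1=O)NO`, have all been tested in a functional assay on NCI-H23 cells (Homo sapiens) for inhibition, read by sulforhodamine B assay; a higher number here means a weaker inhibitor of growth, a lower number a stronger inhibitor of growth. In this assay compound 1 gives 2520 nM, compound 2 gives 2520 nM, and compound 3 gives 2500 nM. The three values sit close together, and none of them can be set apart from the others.

Compound 1 and compound 2 differ in a single place: chloro in place of bromo on an aromatic carbon. The step that this change made, no change at the digits printed from compound 1 to compound 2 (within the scatter), is within the scatter of the measurement. The same kind of change connects compound 3 to compound 4, whose structure is `O=C(CCC1=CCN(Cc2cccc(Cl)c2)C1=O)NO` and which has not yet been measured: chloro in place of bromo on an aromatic carbon. In compound 1 the group sits para to a large group, whereas in compound 3 it sits meta to a large group, so the surroundings of the place are not the same word for word, and the change counts as the same kind of change rather than the same change. How the core of compound 3 differs from the core of compound 1 is not broken down here.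

Resting on the flat step from compound 1 to compound 2, the step from compound 3 to compound 4 is expected to be about no change at the digits printed from compound 3 to compound 4 (within the scatter). Compound 4 is therefore estimated at 2500 nM in this assay, with a range from 1250 nM to 5000 nM.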

Compound 4, concentration for 50% growth inhibition: 2500 nM
Compound 4: middle estimate and measured number agree at the digits printed, and the stated range covers the measured number.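

In this assay, the exchange of bromo for chloro on the aromatic ring gives no change at the digits printed from compound 3 to compound 4 (within the scatter), and this new step agrees with the earlier one: the same change on two cores in this assay, no change at the digits printed (within the scatter) from compound 1 to compound 2 and no change at the digits printed (within the scatter) from compound 3 to compound 4, 1.0-fold (0.00 log units) apart, within the scatter of two such steps

Among these four compounds, then, the exchange reads the same on the core of compound 1 and on the core of compound 3, where the halogen stands meta to a large group, so the step carried over from one core to the other in this pair of cases. This does not show that the exchange would read the same on other cores in the series or at other places on the ring, and with both steps within the scatter, the data cannot rule out a small real difference between bromo and chloro or say anything about why none is seen.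

The compounds shown carry only bromo and chloro at this place, which leaves open how a fluoro, a methoxy, a nitrile or an amine there would read on either core. They also leave open how a longer chain on the shared core of compound 3 and compound 4, or a carboxylic acid in place of the hydroxamic acid, would read in this assay.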